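Moving the fluorine around the ring on the amide nitrogen

The source may hold more compounds than are shown below. What is called first, only, known or untested is meant among the compounds shown, and "the series" means these compounds.

Compound 2 `O=C1c2cc(COc3ccccc3)nn2CCN1c1cccc(F)c1` carries a 3-fluorophenyl on an amide-type nitrogen in a ring of the shared core. In a functional assay on HEK293 cells for positive allosteric modulation of metabotropic glutamate receptor 5 (Homo sapiens), read by calcium flux (a higher number here means a larger maximal response, a lower number a smaller maximal response), compound 2 gives 81%. Among the compounds with values here, its only measured neighbour is compound 1 `O=C1c2cc(COc3ccccc3)nn2CCN1c1ccccc1F`, which has a 2-fluorophenyl at the same place; in this assay compound 1 gives 86%. Within the data shown here, the one measured step, a number 5 percentage points lower from compound 1 to compound 2 (within the scatter), shows that exchanging the 2-fluorophenyl for the 3-fluorophenyl did not move the maximal response beyond what repeated measurements of this kind scatter, so compound 2 stands alongside compound 1 rather than apart from it.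

Compound 3 `O=C1c2cc(COc3ccccc3)nn2CCN1c1ccc(F)cc1` is the third member of this trio. It differs from compound 2 as follows: 4-fluorophenyl in place of 3-fluorophenyl on an amide-type nitrogen in a ring. Among the measured compounds shown here, this is the same kind of exchange as the one measured step, a fluorine walked along the phenyl ring on the amide-type nitrogen, and that step was within the scatter. The expected step, a number 1 percentage points higher from compound 2 to compound 3 (within the scatter), is of the same modest size. Compound 3 is therefore estimated to reach 82% in this assay, with a range from 65% to 100%.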

Compound 3, largest response reached (Emax), in percent of the reference or control that the assay uses: 79%
Compound 3: middle estimate off by 3 percentage points, on the high side, within the range that was stated.
By their numbers in this assay, from the lowest: compounds 3, 2 and 1 (each within the scatter of the next).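

In this assay, exchanging the 3-fluorophenyl for the 4-fluorophenyl on the amide-type nitrogen gives a number 2 percentage points lower from compound 2 to compound 3 (within the scatter), and exchanging the 2-fluorophenyl for the 4-fluorophenyl gives a number 7 percentage points lower from compound 1 to compound 3 (within the scatter). The earlier step covered only the 2-fluorophenyl and the 3-fluorophenyl, whereas all three pairs can now be read, and even the largest of the three steps stays within the scatter, so the maximal response does not separate these three fluorophenyl groups at this position. Nothing shown here offers an explanation for this result.

From the compounds shown here alone, what the maximal response would be with a group other than a fluorophenyl at this place, such as an unsubstituted phenyl, a chlorophenyl, a methoxyphenyl or a cyclohexyl, remains open. So does the question of whether the three fluorophenyl compounds also stand together in potency, the concentration at which they act, since only their maximal response is given here.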